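Swapping the benzimidazole on sulfur for a phenylimidazole

This account rests on a few compounds, and the source may have more. Where it says the series, first, only, none or still open, it means among the compounds named here.

Measured in a functional assay on NCI-N87 cells (Homo sapiens) for antiproliferative activity, read by luminescence, with a stated time of 72 h; on this read-out higher numbers stand for weaker inhibition and lower numbers for stronger inhibition:
Compound 1 `CN1CC=C(c2c(O)cc(O)c3c(=O)cc(-c4ccc(Sc5nc6ccccc6[nH]5)cc4)oc23)CC1`: 183 nM
Compound 2 `CN1CC=C(c2c(O)cc(O)c3c(=O)cc(-c4ccc(Sc5nc6ccccc6[nH]5)cc4Cl)oc23)CC1`: 12 nM

Of these two, compound 1 gives the higher number, 183 nM, and so the weaker inhibition. Among the measured compounds shown here, the only measured step, a 15-fold lower number from compound 1 to compound 2 (1.18 log units; beyond the scatter), is large, but it is chloro in place of hydrogen on an aromatic carbon. Compound 3 `CN1CC=C(c2c(O)cc(O)c3c(=O)cc(-c4ccc(Sc5nc(-c6ccccc6)c[nH]5)cc4)oc23)CC1` differs from compound 1 elsewhere, with 4-phenyl-1H-imidazol-2-yl in place of 1H-benzimidazol-2-yl on a sulfur. For the measured compounds named here, no measured step touches that place, so the chloro step shows only that a single change can move this assay strongly and gives no direction here. In this assay no step beyond the scatter is therefore expected, and the estimate is a 1.1-fold higher number from compound 1 to compound 3 (0.04 log units; within the scatter), with wide uncertainty on both sides. Compound 3 is expected at 200 nM, within a range of 50 nM to 800 nM.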

Compound 3, half-maximal inhibitory concentration: 4800 nM
Beside the measured number, compound 3's estimate is 24-fold (1.38 log units) below it, outside the stated range (above it).
By their numbers in this assay, from the lowest: compound 2; then compound 1; then compound 3.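

In this assay the group on the sulfur proves to matter strongly: 4-phenyl-1H-imidazol-2-yl in place of 1H-benzimidazol-2-yl gives a 26-fold higher number from compound 1 to compound 3 (1.42 log units; beyond the scatter) and so much weaker inhibition. The two groups have the same kinds of aromatic ring and the same hydrogen-bond donor and acceptor counts, so these shared features do not keep the number in place. Nothing available explains this loss of inhibition.

The compounds shown do not separate the contribution of the phenyl from that of the change in how the rings are joined, a question that a plain 1H-imidazol-2-yl could address. They also leave open whether the chloro change seen in compound 2 would lower the number of compound 3, and how an amine on the benzimidazole would behave.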